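The source may hold more compounds than are shown below. What is called first, only, known or untested is meant among the compounds shown, and "the series" means these compounds.

Working notes on the series. In an ADME assay on cells (Erythrocyte, Homo sapiens), read by spectrophotometry and hemolysis, with a stated time of 24 h (on this read-out higher numbers stand for weaker inhibition and lower numbers for stronger inhibition), compound 1 `CC1(C)[N+]([O-])=c2ccc(COc3ccc(/C=N/NC(N)=S)cc3)cc2=[N+]1[O-]` gives "nd(insoluble)" (no result reported), so it provides no number. Compound 2 `C=CCNC(=S)N/N=C/c1ccc(OCc2ccc3c(c2)=[N+]([O-])C(C)(C)[N+]=3[O-])cc1` reads > 100 uM in this assay. That value is a limit of the assay and not a number, so the standing of compound 2 is known only as a limit.

Compound 3 `CC1(C)[N+]([O-])=c2ccc(COc3ccc(/C=N/NC(=S)Nc4ccccc4)cc3)cc2=[N+]1[O-]` has not yet been measured. It differs from compound 2 by phenyl in place of allyl on an amide-type nitrogen. Among the compounds with values here, the series contains no measured step for this or any other change, so the size of the step cannot be taken from a measured pair. The expectation rests on compound 2 alone, and no step beyond the scatter is expected in this assay. A report of compound 3 as a limit would be no surprise. The expected change is a step that the limit leaves unreadable from compound 2 to compound 3, an estimate that stays within the usual scatter of the assay. For compound 3 the estimated value is 150 uM, with an expected range of 50 uM to 400 uM.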

Compound 3, concentration for 50% inhibition: < 50 uM
Compound 3: only a limit was reported; the forecaster's own chance of this, stated with the estimate: 75%; at least 3.0-fold (0.47 log units) between middle value and limit.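

Phenyl in place of allyl on an amide-type nitrogen gives the first step in the series that can be read at all in this assay: an at least 2.0-fold lower number from compound 2 to compound 3 (0.30 log units; that floor lies within the scatter). This shows that the group on this nitrogen, whose other neighbour is the thiocarbonyl carbon, can go with a lower reported limit, but the printed floor of the step lies within the scatter, so the data do not establish a change beyond it. The reading for compound 3 is itself a limit of the assay and not a number: the limit of < 50 uM in this assay, at which 1 of the 3 values shown sits.

As far as these compounds go, the true size of the step remains open, as does whether it follows the aromatic ring or simply the larger group, since phenyl differs from allyl in both respects and compound 1 supplies no number for comparison. A cyclohexyl group on the same nitrogen would keep the carbon count of phenyl without the aromatic ring, while a benzyl group or a phenyl ring carrying an amine or a carboxylic acid would test how far the step extends.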